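Branching the Propoxy Chain: From Compound 2 to Compound 3

The source may hold more compounds than are shown below. What is called first, only, known or untested is meant among the compounds shown, and "the series" means these compounds.

Measured compounds:
compound 1 `CCOC(=O)c1c(-c2cccc(C)c2)[nH]c2cc(OC)ccc2c1=O` — > 21500 nM
compound 2 `CCCOc1cccc(-c2[nH]c3cc(OC)ccc3c(=O)c2C(=O)OCC)c1` — > 21500 nM

In an ADME assay on HepG2 cells (Homo sapiens) for cytotoxicity, read by luminescence, with a stated time of 72 h (a lower number here means that less compound is needed, a higher number that more compound is needed for the effect), compound 1 gives > 21500 nM, which is a limit of the assay and not a number. Compound 2 gives in this assay > 21500 nM, again a limit. Within the data shown here, compound 2 therefore stands only at a limit, and the one other value shown is a limit as well. The step that the two limits leave unreadable from compound 1 to compound 2 cannot be read because both of its ends sit on (the limit of > 21500 nM in this assay, at which 2 of the 2 values shown sit).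

Compound 3 `CCOC(=O)c1c(-c2cccc(OCC(C)C)c2)[nH]c2cc(OC)ccc2c1=O` differs from compound 2 by methyl in place of hydrogen on a saturated chain carbon bound to two saturated chain carbons. Among the measured compounds shown here, no measured step bears on this change: the single step measured in this assay is unreadable, so there is nothing to set a size or direction against. What can be expected rests on the two limits alone, and the most likely outcome is that compound 3 reports a limit once more, with the expected step that the limit leaves unreadable from compound 2 to compound 3 not readable beyond the scatter. Compound 3 is therefore estimated at 30000 nM in this assay, within a range of 15000 nM to 80000 nM.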

Compound 3, half-maximal effective concentration: > 21500 nM
Compound 3: a limit, no number (the forecaster's own chance of this, stated with the estimate: 80%); the middle value lies beyond the limit too.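

In this assay, compound 3 gives > 21500 nM, a limit of the assay and not a number. Among these compounds, no step among compound 1, compound 2 and compound 3 can therefore be read: the limit of > 21500 nM in this assay, at which 3 of the 3 values shown sit. The compounds shown leave open whether methyl, propoxy and isobutoxy on the shared core differ at all in half-maximal effective concentration.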